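Methoxy for methyl on the aryl hydrazone of compound 1

The source may report more compounds than this note shows. Statements on the series, on what has been measured and on what is new or still open speak of the compounds shown alone.

Compound 1 `Cc1ccc(/C=N/NC(=O)COc2cccc3ccccc23)cc1` is one of three hydrazones sharing a naphthyloxy-acetyl core. In an ADME assay on MT4 cells (Homo sapiens) for cytotoxicity, read by MTT assay, with a stated time of 4 days (on this read-out lower numbers stand for higher toxicity in this test and higher numbers for lower toxicity in this test), compound 1 gives 83.9 ug/mL, the highest of the three numbers. Compound 2 `C/C(=N\NC(=O)COc1cccc2ccccc12)c1ccc(O)cc1` gives 68.8 ug/mL, a value within the scatter of compound 1. Among the compounds with values here, compound 3 `C/C(=N\NC(=O)COc1cccc2ccccc12)c1cccc([N+](=O)[O-])c1` gives 12.1 ug/mL, the only number clearly below the others; the step of a 5.7-fold lower number from compound 2 to compound 3 (0.75 log units; beyond the scatter) is the one step measured here. Compound 4 `COc1ccc(/C=N/NC(=O)COc2cccc3ccccc23)cc1` differs from compound 1 as follows: methoxy in place of methyl on an aromatic carbon. Within the data shown here, no measured step involves this change, and the only measured step concerns a different group on a different ring position, so it offers little guidance. Compounds 1 and 2 show that two different groups at this end of the molecule give numbers within the scatter of each other. Compound 4 is therefore expected to stay close to compound 1, with a step of a 1.1-fold lower number from compound 1 to compound 4 (0.05 log units; within the scatter) that is not beyond the scatter. For compound 4 the estimated value is 75 ug/mL, with a range from 40 ug/mL to 140 ug/mL.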

Compound 4, half-maximal cytotoxic concentration: 76.9 ug/mL
The estimate for compound 4 lay 1.0-fold (0.01 log units) below the measured number; the range from low to high includes it.
By their numbers in this assay, from the lowest: compound 3; then compounds 2, 4 and 1 (each within the scatter of the next).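

In this assay, replacing methyl with methoxy at this ring position gives a 1.1-fold lower number from compound 1 to compound 4 (0.04 log units; within the scatter), so the change from 4-methylphenyl to 4-methoxyphenyl leaves compound 4 indistinguishable from compound 1. Within the data shown here, this is the first direct comparison at this position, and it shows that a larger group carrying an oxygen, counted as a hydrogen-bond acceptor, can enter there with no change beyond the scatter. No measurement shown here explains why the number holds.

The only step shown beyond the scatter is a 5.7-fold lower number from compound 2 to compound 3 (0.75 log units; beyond the scatter), and it comes from a different pair, so it remains open whether a nitro group at this position on compound 1 would produce a similar step. Also open, from the compounds shown here alone, is whether an amine, a carboxylic acid or a longer chain such as butoxy would keep the number within the scatter.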